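Amino on the Core: From Compound 3 to Compound 4

The source may hold more compounds than are shown below. What is called first, only, known or untested is meant among the compounds shown, and "the series" means these compounds.

Of the compounds shown here, three have so far been measured in a functional assay on NCI-H23 cells (Homo sapiens) for cytotoxicity, read by sulforhodamine B assay, with a stated time of 48 h; a higher number here means that more compound is tolerated, a lower number that less compound is tolerated. Compound 1 `ClCc1ccc(Cn2cnc3c(Cl)ncnc32)cc1` gives 7760 nM. Compound 2 `Nc1nc(Cl)c2ncn(Cc3ccc(CCl)cc3)c2n1` carries one change relative to compound 1, namely (amino in place of hydrogen on an aromatic carbon), and in this assay compound 2 gives 77600 nM. That single change produced a 10-fold higher number from compound 1 to compound 2 (1.00 log units; beyond the scatter). Compound 3 `ClCc1ccccc1Cn1cnc2c(Cl)ncnc21` gives in this assay 9330 nM; its value and that of compound 1 lie within the scatter of each other, so no order between them is claimed. Compound 3 is built from the same atoms as compound 1, joined differently, and the difference between the two cores is not broken down here.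

Compound 4 `Nc1nc(Cl)c2ncn(Cc3ccccc3CCl)c2n1` has not yet been measured. For the measured compounds named here, it differs from compound 3 by amino in place of hydrogen on an aromatic carbon, and this is the same change, at a place described in identical words, as the one that took compound 1 to compound 2. Among the compounds shown, the change occurs twice in all, and only one of the two pairs has a measured step. The expectation for compound 4 therefore rests on that single measured pair, where the same change gave a 10-fold higher number from compound 1 to compound 2 (1.00 log units; beyond the scatter). On that basis compound 4 is expected to give about 90000 nM in this assay, with a plausible range from 35000 nM to 230000 nM. For compound 4 this estimate means an expected step of a 9.6-fold higher number from compound 3 to compound 4 (0.98 log units; beyond the scatter).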

Compound 4, concentration lethal to 50% of the cells: 78900 nM
Compound 4: middle estimate off by 1.1-fold (0.06 log units), on the high side; the measured number falls inside the stated range.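

In this assay, amino in place of hydrogen on an aromatic carbon gives an 8.5-fold higher number from compound 3 to compound 4 (0.93 log units; beyond the scatter), so the change now has a second measured reading on a second core. Set beside the earlier reading, the two steps do not differ beyond what repeated measurements would allow: the same change on two cores in this assay, a 10-fold higher number (1.00 log units; beyond the scatter) from compound 1 to compound 2 and an 8.5-fold higher number (0.93 log units; beyond the scatter) from compound 3 to compound 4, 1.2-fold (0.07 log units) apart, within the scatter of two such steps

For the compounds shown here, in this small series, then, the change carried from the core of compound 1 to the core of compound 3 with much the same size, and a step read on one of these cores would have served for the other; this rests on only two pairs, however, and it neither shows that the step would hold on any further core nor explains why more compound is tolerated once amino is present.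

The compounds shown leave open whether a different group on the same aromatic carbon, such as methylamino, dimethylamino or hydroxyl, would give a step of similar size or a different one. They also leave open whether the amino step would persist if the chloromethyl group gave way to a plain methyl group or a bromomethyl group.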